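The compounds below may be only part of what the source reports. "The series", "measured", "known", "first", "only" and "open" are said of these compounds alone.

- Compound 1 `CCCN(CCC)CCCOc1ccc2cc(NC(=O)c3ccc(O)c(CC=C(C)C)c3)c(=O)oc2c1C`: > 50000 nM
- Compound 2 `CC(C)=CCc1cc(C(=O)Nc2cc3ccc(OCCCNCc4ccccc4)c(C)c3oc2=O)ccc1O`: 910 nM
- Compound 3 `CC(C)=CCc1cc(C(=O)Nc2cc3ccc(OCCCN[C@H](C)c4ccccc4)c(C)c3oc2=O)ccc1O`: not yet measured

In a functional assay on MCF7 cells (Homo sapiens) for antiproliferative activity (a lower number here means a stronger inhibitor, a higher number a weaker inhibitor), compound 1 gives > 50000 nM, which is a limit. Within the data shown here, compound 2 gives 910 nM, the only exact number so far. Compound 3 differs from it by methyl in place of hydrogen on a saturated chain carbon bound to an amine nitrogen and an aromatic carbon. Among the measured compounds shown here, one measured step bears on this amine substituent: an at least 54-fold lower number from compound 1 to compound 2 (1.73 log units; beyond the scatter), which is large. That step exchanged a whole group, so a much smaller change is expected here, leaning slightly towards weaker inhibition in this assay. The expected step is a 1.3-fold higher number from compound 2 to compound 3 (0.12 log units; within the scatter). Compound 3 is estimated at 1200 nM, with an expected range of 400 nM to 5000 nM.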

Compound 3, half-maximal inhibitory concentration: 1450 nM
Beside the measured number, compound 3's estimate is 1.2-fold (0.08 log units) below it, and the stated range covers the measured number.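

In this assay, methyl in place of hydrogen on the saturated chain carbon bound to an amine nitrogen and an aromatic carbon gives a 1.6-fold higher number from compound 2 to compound 3 (0.20 log units; within the scatter), so the two cannot be told apart and this carbon accepts a methyl branch. The (1-phenylethyl)amino group also holds the advantage over dipropylamino, with an at least 34-fold lower number from compound 1 to compound 3 (1.53 log units; beyond the scatter). The value of compound 1 is a limit: the limit of > 50000 nM in this assay, at which 1 of the 3 values shown sits.

Going by these compounds, it remains open how the mirror-image form of the (1-phenylethyl)amino group, or an ethyl group on this same carbon, would behave.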